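This account rests on a few compounds, and the source may have more. Where it says the series, first, only, none or still open, it means among the compounds named here.

Compound 1 `CCOC(=O)c1sc2nc(-c3ccccc3)cc(C(F)(F)F)c2c1N` stands at the limit of the assay: in an ADME assay on Huh-7 cells (Homo sapiens) for cytotoxicity, read by MTT assay, with a stated time of 72 h (on this read-out higher numbers stand for lower toxicity in this test and lower numbers for higher toxicity in this test), compound 1 gives > 20000 nM, a limit and not a number. Compound 2 `CCOC(=O)c1sc2nc(C3CC3)cc(C(F)(F)F)c2c1N` likewise gives > 20000 nM in this assay, again a limit. Compound 3 `CCOC(=O)c1oc2nc(-c3cccs3)cc(C(F)(F)F)c2c1N` gives > 20000 nM in this assay, also a limit. The step that the two limits leave unreadable from compound 1 to compound 2 is thus unreadable, and the limit of > 20000 nM in this assay, at which 3 of the 3 values shown sit, holds every value shown so far. Compound 4 `Nc1c(C(=O)NCc2ccccc2)sc2nc(-c3ccccc3)cc(C(F)(F)F)c12` differs from compound 1 by benzylamino in place of ethoxy on a carbonyl carbon. For the measured compounds named here, no measured step bears on this change, and no step has a readable size. The expectation for compound 4 is that the step that the limit leaves unreadable from compound 1 to compound 4 stays small, with the assay again likely to report only a limit. Compound 4 is therefore estimated at 30000 nM, between 8000 nM and 100000 nM.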

Compound 4, half-maximal cytotoxic concentration: > 20000 nM
Compound 4 ended at the assay's limit; the forecaster's own chance of this, stated with the estimate: 80%; the middle value is on the limit's open side.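

No step can be read from compound 1 to compound 4, since both stand only as limits in this assay: the limit of > 20000 nM in this assay, at which 4 of the 4 values shown sit. The compounds shown leave open at what concentration, if any, each becomes cytotoxic in this assay.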